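The source may report more compounds than this note shows. Statements on the series, on what has been measured and on what is new or still open speak of the compounds shown alone.

Measured so far:
- compound 1 `COc1cc(Nc2ncccc2-c2nc(Nc3cc(OC)ccc3OC)n[nH]2)cc(OC)c1`: > 10000 nM
- compound 2 `COc1cc(Nc2n[nH]c(-c3cccnc3Nc3cc(OC)cc(OC)c3)n2)cc(OC)c1`: "not determined" (no result reported)

In a functional assay on A-431 cells (Homo sapiens) (a higher number here means that more compound is needed for the effect, a lower number that less compound is needed), compound 2 has no number and stands at "not determined" (no result reported). Compound 1 gives > 10000 nM, which is a limit and not a number. Within the data shown here, the only guide for the series is the limit of > 10000 nM in this assay, at which 1 of the 2 values shown sits.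

Compound 3 `COc1cccc(CNc2n[nH]c(-c3cccnc3Nc3cc(OC)cc(OC)c3)n2)c1` carries 3-methoxybenzyl in place of 3,5-dimethoxyphenyl on a nitrogen on an aromatic ring. Among the measured compounds shown here, no measured step covers this change, so in this assay the expected step is none beyond the scatter. Compound 3 is expected at about 10000 nM, with an estimated range of 3000 nM to 30000 nM.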

Compound 3, half-maximal effective concentration: 120 nM
Estimate against measurement, compound 3: 83-fold (1.92 log units) above; the measured number lies below the stated range.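

In this assay, exchanging 2,5-dimethoxyphenyl for 3-methoxybenzyl gives an at least 83-fold lower number from compound 1 to compound 3 (1.92 log units; beyond the scatter). Compound 1 stands at > 10000 nM, which is a limit of the assay, and the step rests on it: the limit of > 10000 nM in this assay, at which 1 of the 3 values shown sits.
Among the compounds shown, a measured number at this position appears only with 3-methoxybenzyl.

The step from compound 2 to compound 3 cannot be read, so 3,5-dimethoxyphenyl and 3-methoxybenzyl remain uncompared. As far as these compounds go, whether the benzyl link or the methoxy group carries the change stays open, as does the outcome with unsubstituted benzyl or a pyridylmethyl group.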